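From iodo to methoxy on a shared core

The source may hold more compounds than are shown below. What is called first, only, known or untested is meant among the compounds shown, and "the series" means these compounds.

- compound 1 `NC(=O)c1cc(Cl)ccc1NC(=O)COc1ccccc1`: 1740 nM
- compound 2 `NC(=O)c1cc(I)ccc1NC(=O)COc1ccccc1`: 349 nM

In a functional assay on HT-29 cells (Homo sapiens) for inhibition (a higher number here means a weaker inhibitor of growth, a lower number a stronger inhibitor of growth), compound 2 has the lower of the two measured numbers. Compound 3 `COc1ccc(NC(=O)COc2ccccc2)c(C(N)=O)c1` departs from it as follows: methoxy in place of iodo on an aromatic carbon. Among the compounds with values here, only one measured step bears on this place, a 5.0-fold lower number from compound 1 to compound 2 (0.70 log units; beyond the scatter), which lies beyond the scatter and involves only chloro and iodo. Within the data shown here, no methoxy compound has been measured, so the guide is indirect. Leaving iodo is expected to lose much of that modest step, moving back toward a higher number. The expected change is a 4.3-fold higher number from compound 2 to compound 3 (0.63 log units; beyond the scatter). Compound 3 is estimated at 1500 nM, within an expected range of 450 nM to 5000 nM.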

Compound 3, concentration for 50% growth inhibition: 388 nM
Compound 3: middle estimate off by 3.9-fold (0.59 log units), on the high side, and the stated range ends above it.
By their numbers in this assay, from the lowest: compounds 2 and 3 (each within the scatter of the next); then compound 1.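

In this assay, methoxy at this place, para to a large group, stands level with iodo (a 1.1-fold higher number from compound 2 to compound 3 (0.05 log units; within the scatter)), so the advantage over chloro is not confined to iodo (a 4.5-fold lower number from compound 1 to compound 3 (0.65 log units; beyond the scatter)). The two groups share this standing although they differ in their atoms and in hydrogen-bond acceptors. Nothing available accounts for this result.

From the compounds shown here alone, it remains open whether an amine, a carboxylic acid or a longer ether chain such as ethoxy at this place would stay level with compound 2 and compound 3 or fall back toward compound 1.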